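Bromophenyl Isomers on a Shared Core

The source may report more compounds than this note shows. Statements on the series, on what has been measured and on what is new or still open speak of the compounds shown alone.

Of the compounds shown here, three built on one shared core have been tested in a functional assay on HT-29 cells (Homo sapiens) for cytotoxicity, read by MTT assay, with a stated time of 72 h; a higher number here means a weaker inhibitor, a lower number a stronger inhibitor. Compound 1 `O=C(CN1CCN(c2nnc(Cc3ccccc3)c3ccccc23)CC1)Nc1c(F)cccc1F` gives 19700 nM. Compound 2 `Cc1ccc(F)cc1NC(=O)CN1CCN(c2nnc(Cc3ccccc3)c3ccccc23)CC1` gives 171000 nM, and compound 3 `O=C(CN1CCN(c2nnc(Cc3ccccc3)c3ccccc23)CC1)Nc1ccc(Br)cc1` gives 60200 nM. Among these three numbers compound 3 stands second highest: its nearest neighbour is compound 2, separated by a 2.8-fold lower number from compound 2 to compound 3 (0.45 log units; beyond the scatter), while compound 1 lies furthest away, separated by a 3.1-fold higher number from compound 1 to compound 3 (0.49 log units; beyond the scatter). The third measured step, an 8.7-fold higher number from compound 1 to compound 2 (0.94 log units; beyond the scatter), also came from exchanging the aryl group on the amide-type nitrogen.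

Compound 4 `O=C(CN1CCN(c2nnc(Cc3ccccc3)c3ccccc23)CC1)Nc1cccc(Br)c1` has not yet been measured. It differs from compound 3 in one place only: 3-bromophenyl in place of 4-bromophenyl on an amide-type nitrogen. Among the compounds with values here, no measured pair swaps one bromophenyl for another, so none of the three steps speaks directly to this change. What they do show is that every exchange of the aryl group on the amide-type nitrogen shifted the number in this assay by a modest amount, beyond the scatter but never dramatically. For compound 4 a step of similar modest size is therefore expected, a 1.2-fold lower number from compound 3 to compound 4 (0.08 log units; within the scatter), in a direction that cannot be told from these data. Compound 4 is estimated at 50000 nM, within a range from 15000 nM to 160000 nM.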

Compound 4, half-maximal inhibitory concentration: 13400 nM
Beside the measured number, compound 4's estimate is 3.7-fold (0.57 log units) above it; measured number outside the range, below it.
By their numbers in this assay, from the lowest: compounds 4 and 1 (each within the scatter of the next); then compound 3; then compound 2.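

Moving the bromine alone, with the same atoms joined differently, gives a 4.5-fold lower number from compound 3 to compound 4 (0.65 log units; beyond the scatter) in this assay, so on this amide-type nitrogen the number depends on where the bromine sits on the phenyl ring as well as on which atoms the group contains. Within the data shown here, this single move also brings the bromophenyl series into the range of the difluorinated compound: a 1.5-fold lower number from compound 1 to compound 4 (0.17 log units; within the scatter) leaves the 3-bromophenyl and 2,6-difluorophenyl groups indistinguishable here, while a 13-fold lower number from compound 2 to compound 4 (1.11 log units; beyond the scatter) is the only large step among the four compounds. Nothing measured here explains why the two bromophenyl isomers differ.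

The compounds shown leave open whether this dependence on position belongs to bromine specifically, or whether a chlorine, a methoxy group or a nitrile in place of the bromine in the 3-bromophenyl group would give a similar number. Going by these compounds, it also remains open whether the number for the ((3-bromophenyl)carbamoyl)methyl group would hold with a longer chain in place of the methyl link, and whether the difference between the isomers would appear in any test other than this assay.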